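Compound 3 and the amide group of compound 2

The compounds below may be only part of what the source reports. "The series", "measured", "known", "first", "only" and "open" are said of these compounds alone.

Of the compounds shown here, two sharing one core have numbers so far in an ADME assay on LLC-MK2 cells (Macaca mulatta) for cytotoxicity, read by spectrophotometry and crystal violet staining, with a stated time of 4 days (on this read-out lower numbers stand for higher toxicity in this test and higher numbers for lower toxicity in this test), on record. Compound 1 (`CC(C)n1ncc2c(C(=O)Nc3ccncc3)cc(-c3cccs3)nc21`) gives 6300 nM there, and compound 2 (`CC(C)n1ncc2c(C(=O)N3CCc4cccnc43)cc(-c3cccs3)nc21`) gives 50000 nM as the higher of the two numbers, so it is the less toxic in this test. Compound 3 (`CC(C)n1ncc2c(C(=O)Nc3ccc(F)c(F)c3)cc(-c3cccs3)nc21`) has not yet been measured. Its change from compound 2 lies on a carbonyl carbon whose other neighbour is an aromatic carbon: a group of 9 heavy atoms (6 carbon, 1 nitrogen, 2 fluorine; one six-membered aromatic ring of carbon only) in place of a group of 9 heavy atoms (7 carbon, 2 nitrogen; one five-membered non-aromatic ring with 1 hetero atom, one six-membered aromatic ring with 1 hetero atom), on a carbonyl carbon is what differs, and the five-membered non-aromatic ring goes. Going by the values given here, the only measured step that bears on this is a 7.9-fold higher number from compound 1 to compound 2 (0.90 log units; beyond the scatter) with that same group entering, a modest step beyond the scatter. Among the compounds with values here, compound 3 gives the group up again, yet no measured compound carries the (3,4-difluorophenyl)amino group, so this step is only a rough guide. A move toward compound 1 at 6300 nM is therefore expected in this assay rather than no change. The expected move is a 4.2-fold lower number from compound 2 to compound 3 (0.62 log units; beyond the scatter) and somewhat smaller than the step just named. For compound 3 the estimate is 12000 nM with an expected range from 4000 nM to 40000 nM in this test.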

Compound 3, half-maximal cytotoxic concentration: > 200000 nM
Compound 3: only a limit was reported (the forecaster's own chance of this, stated with the estimate: 15%); middle value at least 16-fold (1.22 log units) away from the limit.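

The value for compound 3 in this assay is a limit and not a number: the limit of > 200000 nM in this assay, at which 1 of the 3 values shown sits. Removing the five-membered non-aromatic ring did not lower the number at this carbonyl carbon, as the earlier step had suggested it might; the change instead gave an at least 4.0-fold higher number from compound 2 to compound 3 (0.60 log units; beyond the scatter), so that ring is not needed for a high number in this test. With the amide hydrogen kept, replacing pyridin-4-yl with 3,4-difluorophenyl on the amide-type nitrogen gave an at least 31-fold higher number from compound 1 to compound 3 (1.50 log units; beyond the scatter), which shows that a change in the aromatic ring alone can move this read-out strongly toward lower toxicity in this test.

The compounds shown leave open whether this step follows the two fluorines or the loss of the ring nitrogen of pyridin-4-yl, a question that a plain phenyl or a 4-fluorophenyl group on the same nitrogen would help to separate. They also leave open how an amine or a carboxylic acid on the phenyl ring would read in this assay.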